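Piperidinyl for piperazinyl on the benzamide ring

The source may hold more compounds than are shown below. What is called first, only, known or untested is meant among the compounds shown, and "the series" means these compounds.

Measured in a functional assay on a cell-free system (Platelet, plasma, Homo sapiens) for inhibition; a lower number here means a stronger inhibitor, a higher number a weaker inhibitor:
compound 1 `O=C(O)CCN1Cc2ccc(NC(=O)c3ccc(C4CCNCC4)cc3)cc2C1=O` 9600 nM
compound 2 `CC(CC(=O)O)N1Cc2ccc(NC(=O)c3ccc(N4CCNCC4)cc3)cc2C1=O` 3740 nM
compound 3 `O=C(O)CN1Cc2ccc(NC(=O)c3ccc(N4CCNCC4)cc3)cc2C1=O` 3300 nM

Compound 2 stands second highest of the three numbers. Its nearest neighbour is compound 3, reached by a 1.1-fold lower number from compound 2 to compound 3 (0.05 log units; within the scatter) on the amide-type nitrogen in a ring, a step within the scatter. Going by the values given here, its furthest neighbour is compound 1, whose value in this assay is the highest of the three and beyond the scatter from compound 2; compounds 1 and 2 differ in two places, so no single step connects them.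

Compound 4 `CC(CC(=O)O)N1Cc2ccc(NC(=O)c3ccc(C4CCNCC4)cc3)cc2C1=O` is not yet measured. It differs from compound 2 thus: piperidin-4-yl in place of piperazin-1-yl on an aromatic carbon. Among the compounds with values here, no measured step follows this change on its own. Within the data shown here, the only compound carrying piperidin-4-yl is compound 1, and no measured pair isolates the chain on the amide-type nitrogen from the ring on the aromatic carbon, so the two contributions cannot be separated.

For compound 4 a somewhat higher number than compound 2 is expected, estimated as a 1.9-fold higher number from compound 2 to compound 4 (0.27 log units; within the scatter), because compound 1 with piperidin-4-yl gives 9600 nM in this assay. The estimate for compound 4 is 7000 nM, ranging from 3000 nM to 16000 nM.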

Compound 4, half-maximal inhibitory concentration: 6200 nM
Compound 4: the middle estimate sits 1.1-fold (0.05 log units) above what was measured, and the stated range covers the measured number.
By their numbers in this assay, from the lowest: compounds 3, 2, 4 and 1 (each within the scatter of the next, the first and the last beyond it).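

In this assay the swap on the aromatic carbon, para to a large group, now has a measured pair: a 1.7-fold higher number from compound 2 to compound 4 (0.22 log units; within the scatter) and so piperidin-4-yl and piperazin-1-yl are not told apart at this position when the chain on the amide-type nitrogen is held constant. Going by these compounds alone, the second pair isolates that chain for the first time with piperidin-4-yl on the ring: a 1.5-fold lower number from compound 1 to compound 4 (0.19 log units; within the scatter) and the added methyl on the saturated chain carbon is likewise not resolved by this assay. No evidence on hand accounts for either step.

Still open, from the compounds shown here alone, is whether morpholin-4-yl, with a ring oxygen in place of the ring amine, would remain within the scatter of compound 2 on the same aromatic carbon. Also open, going by these compounds, is how an ester in place of the carboxylic acid would read on this chain.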